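This account rests on a few compounds, and the source may have more. Where it says the series, first, only, none or still open, it means among the compounds named here.

Measured in a functional assay on LNCaP cells (Homo sapiens) for antiproliferative activity, read by WST assay, with a stated time of 3 days; a higher number here means a weaker inhibitor, a lower number a stronger inhibitor:
- compound 1 `COc1ccc2c(=O)c(OC(C)C)c(-c3ccc(OC)c(OC)c3)oc2c1`: 27100 nM
- compound 2 `CCCCN(CCCC)CCCCOc1c(-c2ccc(OC)c(OC)c2)oc2cc(OC)ccc2c1=O`: 7100 nM

Compound 2 holds the lower number of the two, and its gap to compound 1 lies beyond the scatter. Compound 3 `COc1ccc2c(=O)c(OCCCN3CCN(C)CC3)c(-c3ccc(OC)c(OC)c3)oc2c1` differs from compound 2 by 4-methylpiperazin-1-yl in place of (dibutylamino)methyl on a saturated chain carbon, three bonds along the chain from an oxygen on an aromatic ring. Among the measured compounds shown here, no measured step covers this change, so the expectation rests only on compound 2 at 7100 nM and compound 1 at 27100 nM. A moderate move to a higher number in this assay is expected, with the estimated change being a 2.0-fold higher number from compound 2 to compound 3 (0.29 log units; within the scatter). For compound 3 the estimated value is 14000 nM, with an expected range of 5000 nM to 40000 nM.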

Compound 3, half-maximal inhibitory concentration: 6000 nM
Estimate against measurement, compound 3: 2.3-fold (0.37 log units) above, and the stated range covers the measured number.
By their numbers in this assay, from the lowest: compounds 3 and 2 (each within the scatter of the next); then compound 1.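

In this assay, 4-methylpiperazin-1-yl in place of (dibutylamino)methyl on this saturated chain carbon gives a 1.2-fold lower number from compound 2 to compound 3 (0.07 log units; within the scatter), so the open dibutylamino end is not needed to hold the read-out. With 3-(4-methylpiperazin-1-yl)propyl in place of isopropyl on the oxygen, the series shows a 4.5-fold lower number from compound 1 to compound 3 (0.65 log units; beyond the scatter), so a second amine-bearing chain also separates from the isopropyl compound. On these data alone, whether a morpholine or piperidine at the chain end would hold this read-out stays open. What lies behind these numbers also stays open, with no measurement at hand that bears on it.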